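The compounds below may be only part of what the source reports. "The series", "measured", "known", "first", "only" and "open" are said of these compounds alone.

In a functional assay on Jurkat cells (Homo sapiens) for inhibition, read by CCK-8 assay, with a stated time of 48 h (on this read-out lower numbers stand for stronger inhibition of growth and higher numbers for weaker inhibition of growth), compound 3 (`COc1ccc(CNc2nc(Nc3ccc(N4CCN(C)CC4)cn3)ncc2Cl)cc1`) gives 12900 nM and lies within the scatter of compound 1 (`Cc1ccccc1Nc1nc(Nc2ccc(N3CCN(C)CC3)cn2)ncc1Cl`), which gives 8080 nM here. Compound 2 (`Cc1ccccc1Nc1nc(Nc2ccc(N3CCN(C(=O)OC(C)(C)C)CC3)cc2)ncc1Cl`) at 5120 nM stands lower than compound 3, beyond the scatter. Compound 4 (`Cc1cccc(Nc2nc(Nc3ccc(N4CCN(C)CC4)cn3)ncc2Cl)c1`) carries 3-methylphenyl in place of 4-methoxybenzyl on a nitrogen on an aromatic ring. Going by the values given here, the one measured step at that nitrogen, 4-methoxybenzyl in place of 2-methylphenyl, is a 1.6-fold higher number from compound 1 to compound 3 (0.20 log units; within the scatter) and stays within the scatter. No step beyond the scatter is therefore expected in this assay here. The estimated step is a 1.6-fold lower number from compound 3 to compound 4 (0.21 log units; within the scatter) and would remain within the scatter. Compound 4 is expected at 8000 nM with an estimated range from 3500 nM to 16000 nM on this read-out.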

Compound 4, concentration for 50% growth inhibition: 15300 nM
Beside the measured number, compound 4's estimate is 1.9-fold (0.28 log units) below it; low and high end bracket the measured number.
By their numbers in this assay, from the lowest: compounds 2, 1, 3 and 4 (each within the scatter of the next, the first and the last beyond it).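

In this assay, this nitrogen on an aromatic ring now carries three different groups, and no change among them moves the number beyond the scatter. Both 3-methylphenyl in place of 4-methoxybenzyl (a 1.2-fold higher number from compound 3 to compound 4 (0.07 log units; within the scatter)) and 3-methylphenyl in place of 2-methylphenyl (a 1.9-fold higher number from compound 1 to compound 4 (0.28 log units; within the scatter)) stay within it, so moving from the 2-methylphenyl to the 3-methylphenyl group is not separated from no change here. No evidence on hand bears on this result. Still open, from the compounds shown here alone, is whether an amine or a carboxylic acid on the phenyl ring at this nitrogen would give a step beyond the scatter.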